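Isopropyl in Place of Carboxymethyl on the Amino Acid Carbon

This account rests on a few compounds, and the source may have more. Where it says the series, first, only, none or still open, it means among the compounds named here.

Compound 3 `O=C(O)C[C@H](NC(=O)CN(c1nc(Cl)nc2[nH]cnc12)C1CC1)C(=O)O` is one of three compounds sharing a common core that were measured in a functional assay on the whole organism (Tail, strain ICR) with Mus musculus as the target, in the tail flick test, with a stated time of 30 min, at a dose of 25 umol/kg by the oral route; a higher number here means a stronger effect of the compound at the dose given, a lower number a weaker effect. In this assay compound 3 gives 19.9%, which places it second among the three numbers. Compound 1 `C[C@@H](O)[C@H](NC(=O)CN(c1nc(Cl)nc2[nH]cnc12)C1CC1)C(=O)O` gives 18.6%, and the step of a number 1.3 percentage points higher from compound 1 to compound 3 (within the scatter) is small. Among the compounds with values here, compound 2 `CC(C)[C@H](NC(=O)CN(c1nc(Cl)nc2[nH]cnc12)C1CC1)C(=O)OCc1ccccc1` gives 33.4%, the only value that lies beyond the scatter of compound 3.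

Compound 4 `CC(C)[C@H](NC(=O)CN(c1nc(Cl)nc2[nH]cnc12)C1CC1)C(=O)O` differs from compound 3 in one place: isopropyl in place of carboxymethyl on a saturated chain carbon bound to an amide-type nitrogen and a carbonyl carbon. Within the data shown here, the only measured step at the same place is a number 1.3 percentage points higher from compound 1 to compound 3 (within the scatter), and it stayed within the scatter, so an exchange of the group on that carbon has so far not moved this assay in a way that can be distinguished from noise. Among the measured compounds shown here, compound 2, which also carries the isopropyl, gives 33.4%, but no single step connects it with compound 4, so its value can only hint at a direction.

Compound 4 is therefore expected to land close to compound 3 with a slight lean upward, a number 3.1 percentage points higher from compound 3 to compound 4 (within the scatter), a step that is not expected to exceed the scatter. The estimate for compound 4 in this assay is 23%, with a range from 10% to 38%.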

Compound 4, a percentage reported as activity, at one dose (the size of the read-out at that dose, not a potency): 31.2%
Estimate against measurement, compound 4: 8.2 percentage points below; the measured number falls inside the stated range.
By their numbers in this assay, from the lowest: compounds 1 and 3 (each within the scatter of the next); then compounds 4 and 2 (each within the scatter of the next).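

Within the data shown here, on the saturated chain carbon bound to an amide-type nitrogen and a carbonyl carbon, the choice of group can now be told apart from noise in this assay: isopropyl in place of carboxymethyl gives a number 11.3 percentage points higher from compound 3 to compound 4 (beyond the scatter), and isopropyl in place of 1-hydroxyethyl gives a number 12.6 percentage points higher from compound 1 to compound 4 (beyond the scatter), both modest, whereas the one exchange known before, between the latter two groups, stayed within the scatter. Among these compounds, the benzyl group on the oxygen next to a carbonyl group can also be read for the first time, and with isopropyl on the chain carbon, hydrogen in its place gives a number 2.2 percentage points lower from compound 2 to compound 4 (within the scatter), a step that stays within the scatter. No measurement shown here speaks to the reason for either result.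

From the compounds shown here alone, it remains open whether a longer chain or an amine on that chain carbon would read with compound 4 or with compounds 1 and 3. Also open, going by these compounds, is whether the benzyl group on that oxygen would stay within the scatter with carboxymethyl or 1-hydroxyethyl on the chain carbon.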